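The compounds below may be only part of what the source reports. "The series", "measured", "known", "first", "only" and "open" are said of these compounds alone.

Compound 1 `Cc1cc(C)cc(-n2cc(COC(=O)c3cc4ccccc4[nH]3)nn2)c1` is the starting point. In an ADME assay on HEK293 cells (Homo sapiens) for cytotoxicity, read by MTT assay, with a stated time of 48 h (on this read-out lower numbers stand for stronger inhibition and higher numbers for weaker inhibition), compound 1 gives 12500 nM, the lower of the two plain numbers available. Compound 3 `Cc1cccc(-n2cc(COC(=O)c3cc4ccccc4n3Cc3cn(-c4cccc(C)c4C)nn3)nn2)c1C` gives 14100 nM in this assay, a value that sits within the usual scatter of compound 1. Compound 2 `CCCCc1ccc(-n2cc(COC(=O)c3cc4ccccc4n3Cc3cn(-c4ccc(CCCC)cc4)nn3)nn2)cc1` is a limit of the assay rather than a number, reported as > 200000 nM in this assay; this matches (the limit of > 200000 nM in this assay, at which 1 of the 3 values shown sits). Compound 4 `COc1ccc(-n2cc(COC(=O)c3cc4ccccc4[nH]3)nn2)cc1` has not yet been tested; it differs from compound 1 by 4-methoxyphenyl in place of 3,5-dimethylphenyl on an aromatic nitrogen. Going by the values given here, no measured pair shows this change, so a step beyond the scatter is not expected in either direction. The expected value for compound 4 in this assay is 14000 nM, with a range from 6000 nM to 35000 nM, which means an expected step of a 1.1-fold higher number from compound 1 to compound 4 (0.05 log units; within the scatter).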

Compound 4, half-maximal inhibitory concentration: 42500 nM
The estimate for compound 4 lay 3.0-fold (0.48 log units) below the measured number; the measured number lies above the stated range.
By their numbers in this assay, from the lowest: compounds 1 and 3 (each within the scatter of the next); then compound 4. At a limit, above all of these: compound 2.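

Going by these compounds alone, this is the first pair that isolates the group on this aromatic nitrogen: in this assay, 4-methoxyphenyl in place of 3,5-dimethylphenyl gives a 3.4-fold higher number from compound 1 to compound 4 (0.53 log units; beyond the scatter). The position therefore responds to its group, even with the same number of heavy atoms on both sides and one added hydrogen-bond acceptor. No measured property accounts for this step. This single pair changes the methoxy and the two methyl groups together, leaving open which of them matters. From the compounds shown here alone, how an amine or a carboxylic acid on this phenyl ring would read also remains open.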